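A few compounds are considered here, and "the series" means these few. Any claim that something is new, unique, unknown or untested is made for them only; others in the source may bear on it.

In a functional assay on HL-60 cells (Homo sapiens) for antiproliferative activity, with a stated time of 72 h (a lower number here means a stronger inhibitor, a higher number a weaker inhibitor), compound 1 `OC[C@H]1O[C@@H](n2cnc3c(NCc4cccc(Br)c4)ncnc32)[C@H](O)[C@@H]1O` gives 8000 nM and compound 3 `COc1ccc(CNc2ncnc3c2ncn3[C@@H]2O[C@H](CO)[C@@H](O)[C@H]2O)c(OC)c1` gives 39000 nM as the higher of the two numbers in hand. Compound 2 `COc1cccc(CNc2ncnc3c2ncn3[C@@H]2O[C@H](CO)[C@@H](O)[C@H]2O)c1OC` gives > 166000 nM as a limit, not a number.

Compound 4 `COc1cc(CNc2ncnc3c2ncn3[C@@H]2O[C@H](CO)[C@@H](O)[C@H]2O)cc(OC)c1` carries 3,5-dimethoxyphenyl in place of 2,4-dimethoxyphenyl on a saturated chain carbon bound to a nitrogen on an aromatic ring.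

The measured steps at this place are an at least 20-fold higher number from compound 1 to compound 2 (1.31 log units; beyond the scatter), a 4.9-fold higher number from compound 1 to compound 3 (0.69 log units; beyond the scatter) and an at least 4.2-fold lower number from compound 2 to compound 3 (0.62 log units; beyond the scatter). Among the measured compounds shown here, the last, a swap between dimethoxyphenyl patterns, is the closest precedent, but its direction does not carry over to the new pattern. The expected change is a 1.1-fold lower number from compound 3 to compound 4 (0.05 log units; within the scatter), so no step beyond the scatter is expected, with a wide margin either way. For compound 4 the estimated value is 35000 nM, with an expected range from 11000 nM to 130000 nM.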

Compound 4, half-maximal inhibitory concentration: 20200 nM
Compound 4: middle estimate off by 1.7-fold (0.24 log units), on the high side; measured number inside the range.
By their numbers in this assay, from the lowest: compound 1; then compounds 4 and 3 (each within the scatter of the next). At a limit, above all of these: compound 2.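

Replacing 2,4-dimethoxyphenyl with 3,5-dimethoxyphenyl gives a 1.9-fold lower number from compound 3 to compound 4 (0.29 log units; within the scatter), so these two patterns are not separated here, while an at least 8.2-fold lower number from compound 2 to compound 4 (0.91 log units; beyond the scatter) sets 2,3-dimethoxyphenyl apart from both. That comparison rests on a limit for compound 2, not a number: the limit of > 166000 nM in this assay, at which 1 of the 4 values shown sits. With a 2.5-fold higher number from compound 1 to compound 4 (0.40 log units; beyond the scatter), 3-bromophenyl keeps the lowest number of the series, ahead of the 3,5-dimethoxyphenyl pattern as well.

Still open, from the compounds shown here alone, is whether a single methoxy, a hydroxyl or an amine on the phenyl ring would match 3-bromophenyl. Also open, going by these compounds, is whether another halogen, such as chlorine, would do the same.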